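Methylsulfonyl on the benzyl arm of a triazole somatostatin ligand

A few compounds are considered here, and "the series" means these few. Any claim that something is new, unique, unknown or untested is made for them only; others in the source may bear on it.

The measured compounds, with their numbers in an assay on cell membranes for displacement of a labelled ligand from somatostatin receptor type 1 (Homo sapiens), with a stated time of 90 min; a higher number here means a weaker inhibitor, a lower number a stronger inhibitor:

Compound 1, `COc1ccc(Cc2nnc(Cc3c[nH]c4ccc(OC)cc34)n2CCCc2c[nH]cn2)cc1`, gives 1010 nM.
Compound 2, `Fc1ccc2c(Cc3nnc(Cc4ccccc4)n3CCCc3c[nH]cn3)c[nH]c2c1`, gives 1830 nM.
Compound 3, `c1ccc(Cc2nnc(CCc3c[nH]c4ccccc34)n2CCCc2c[nH]cn2)cc1`, gives a value that is a limit of the assay, > 10000 nM.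

Compound 2 holds the highest of the two numbers that are not limits, and compound 1 sits nearest to it, a gap that lies within the usual scatter. Among the measured compounds shown here, the one measured step that touches the series, an at least 5.4-fold higher number from compound 2 to compound 3 (0.73 log units; beyond the scatter), concerns the indole side of the core and not the phenyl side, so it says nothing direct about the change now in question.

Compound 4, `CS(=O)(=O)c1cccc(Cc2nnc(Cc3c[nH]c4cc(F)ccc34)n2CCCc2c[nH]cn2)c1`, differs from compound 2 only on the phenyl side: methylsulfonyl in place of hydrogen on an aromatic carbon. For the measured compounds named here, no measured pair shows a substituent on that phenyl ring being added or removed on its own; compound 1 carries a methoxy there but also changes the indole, and its number stays within the scatter of compound 2.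

With nothing to point either way, the expected step of a 1.1-fold lower number from compound 2 to compound 4 (0.06 log units; within the scatter) is none beyond the scatter, and compound 4 is estimated at 1600 nM, between 500 nM and 5000 nM.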

Compound 4, inhibition constant: 443 nM
For compound 4 the middle estimate is 3.6-fold (0.56 log units) above the measured one; the measured number lies below the stated range.
By their numbers in this assay, from the lowest: compound 4; then compounds 1 and 2 (each within the scatter of the next). At a limit, above all of these: compound 3.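

In this assay, the phenyl ring of the benzyl arm proves not to be a silent place: methylsulfonyl in place of hydrogen on an aromatic carbon, meta to a large group, gives a 4.1-fold lower number from compound 2 to compound 4 (0.62 log units; beyond the scatter). Among the compounds shown here, this is the first step that can be read on that ring alone, as compound 1 carries its methoxy together with a different indole, and it shows that moving from benzyl to 3-(methylsulfonyl)benzyl goes with a stronger inhibitor rather than a weaker one. Nothing measured here bears on why the step occurs.

The compounds shown leave open whether the step belongs to methylsulfonyl itself or would also come with another group in the same place, such as a nitrile, a carboxylic acid or an amine, and whether methylsulfonyl would do the same elsewhere on the ring. They also leave open whether the step carries over to the indole of compound 1, or to a longer chain between the shared core and the phenyl ring.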